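The source may hold more compounds than are shown below. What is called first, only, known or untested is meant among the compounds shown, and "the series" means these compounds.

In a functional assay on HL-60 cells (Homo sapiens) for antiproliferative activity (a higher number here means a weaker inhibitor of growth, a lower number a stronger inhibitor of growth), compound 1 `COCCCCCCCCCCCCCCC/C=C1/CC(CO)(COC(=O)C(C)(C)C)OC1=O` gives 3.97 ug/mL and compound 2 `COCCCCCCCCCCCCCCC/C=C1\CC(CO)(COC(=O)C(C)(C)C)OC1=O` gives 4.65 ug/mL so compound 2 stands level with compound 1 within the scatter. Among the compounds with values here, the only measured step, a 1.2-fold higher number from compound 1 to compound 2 (0.07 log units; within the scatter) and nothing more, turns a double bond drawn Z into one drawn E, and it says nothing about chain length. Compound 3 `COCCCCCCCCCCC/C=C1\CC(CO)(COC(=O)C(C)(C)C)OC1=O` differs from compound 2 by methoxy in place of 4-methoxybutyl on a saturated chain carbon, ten or more bonds along the chain from a double-bonded chain carbon in the long chain, with methoxy in place of 4-methoxybutyl. Within the data shown here, with no measured step to guide size or direction, the expected change, a 1.1-fold higher number from compound 2 to compound 3 (0.03 log units; within the scatter) as estimated, stays within the scatter in this assay for now. Compound 3 is estimated at 5 ug/mL with an expected range from 2 ug/mL to 14 ug/mL at its ends.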

Compound 3, concentration for 50% growth inhibition: 5.22 ug/mL
For compound 3 the middle estimate is 1.0-fold (0.02 log units) below the measured one, and the stated range covers the measured number.
By their numbers in this assay, from the lowest: compounds 1, 2 and 3 (each within the scatter of the next).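

In this assay, methoxy in place of 4-methoxybutyl on a saturated chain carbon, ten or more bonds along the chain from a double-bonded chain carbon, gives a 1.1-fold higher number from compound 2 to compound 3 (0.05 log units; within the scatter) and so leaves compound 3 level with compound 2. Compounds 1 and 2 differed only at the double bond, so this is the first step shown that touches the long chain. Nothing in the evidence at hand bears on this step.

As far as these compounds go, whether a longer chain, or an amine or a carboxylic acid in place of the methoxy, would stay level remains open. So does whether the double bond drawn Z would stay level on the chain of compound 3.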